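A few compounds are considered here, and "the series" means these few. Any claim that something is new, unique, unknown or untested is made for them only; others in the source may bear on it.

For the measured compounds named here, compound 2, with the structure `C[C@H](C(=O)Nc1nccs1)c1ccc(Cl)cc1`, is the weaker of the two compounds measured so far in a functional assay on CHO cells for agonist activity at Free fatty acid receptor 2 (Homo sapiens), read by cAMP accumulation; a higher number here means a weaker inhibitor, a lower number a stronger inhibitor. In this assay compound 2 gives 46000 nM. Compound 1, with the structure `CC(C)C(C(=O)Nc1nc2ccccc2s1)c1ccc(Cl)cc1`, gives 3000 nM in this assay, a difference that lies well beyond the usual scatter. Compound 1 differs from compound 2 in two places at once, in the group on the saturated chain carbon and in the core attached to the amide, so no single change can be read off from the pair.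

Compound 3, with the structure `C=CC[C@H](C(=O)Nc1nccs1)c1ccc(Cl)cc1`, has not yet been measured. It is built from compound 2 by one change: vinyl in place of hydrogen on a saturated chain carbon, two bonds along the chain from an aromatic carbon and a carbonyl carbon. Going by the values given here, whether the allyl chain will move the number in this assay cannot be read from any single-change step here; the only guide is that compound 1, which also carries more than a methyl on that carbon, gives 3000 nM. The step from compound 2 to compound 3 is therefore expected to be a modest improvement, a 3.1-fold lower number from compound 2 to compound 3 (0.49 log units; beyond the scatter). Compound 3 is expected to give about 15000 nM in this assay, somewhere between 4000 nM and 50000 nM.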

Compound 3, half-maximal inhibitory concentration: 1100 nM
For compound 3 the middle estimate is 14-fold (1.13 log units) above the measured one; the measured number lies below the stated range.
By their numbers in this assay, from the lowest: compound 3; then compound 1; then compound 2.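

With no other part of the molecule changed, this saturated chain carbon proves to be a place where a small addition counts, with a 42-fold lower number from compound 2 to compound 3 (1.62 log units; beyond the scatter) in this assay and a large step in the direction of a stronger inhibitor. The change extends the methyl of compound 2 to the allyl of compound 3, adding only 2 carbon atoms, with no ring, no hydrogen-bond donors or acceptors and no net charge, so a purely carbon addition at this position is enough to produce a shift of this size. Nothing available here explains why the step is so large.

Still open, as far as these compounds go, is whether the gain depends on the double bond of the allyl or only on the length of the chain: a plain propyl chain on this carbon would separate the two, and a longer chain, or a chain ending in an amine or a carboxylic acid, would show how much else this position accepts. From the compounds shown here alone, it is also open whether the allyl would bring a similar step on the core of compound 1.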